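The compounds below may be only part of what the source reports. "The series", "measured", "known", "first", "only" and "open" are said of these compounds alone.

Working notes on the series. Three compounds have been run in a physicochemical assay for permeability, using PAMPA, with a stated time of 4 h, at pH 7.4, tested at 50 uM; on this read-out lower numbers stand for lower permeability and higher numbers for higher permeability: compound 1 `Cc1c(Cl)cccc1CCCCOc1ccc(C#Cc2cccc3c(CC(=O)O)c(C)n(CCCCC(=O)O)c23)cc1`, compound 2 `Cc1c(CCCC(=O)O)c2cccc(/C=C/c3ccc(OCCCCc4c(F)c(F)cc(F)c4F)cc3)c2n1CC(=O)O` and compound 3 `Cc1c(Cl)cccc1CCCCOc1ccc(C#Cc2cccc3c(CCCC(=O)O)c(C)n(CC(=O)O)c23)cc1`. In this assay compound 1 gives 1 10^-6 cm/s, compound 2 gives 0.5 10^-6 cm/s and compound 3 gives 3.2 10^-6 cm/s. Compound 2 thus holds the lowest of the three numbers, though compound 1 sits within the scatter of it; only compound 3 lies beyond the scatter from compound 2. Compound 3 differs from compound 2 in more than one place, so no single step can be read from that pair.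

The next compound, compound 4 `Cc1c(F)cccc1CCCCOc1ccc(/C=C/c2cccc3c(CCCC(=O)O)c(C)n(CC(=O)O)c23)cc1`, differs from compound 2 in one place: 3-fluoro-2-methylphenyl in place of 2,3,5,6-tetrafluorophenyl on a saturated chain carbon, four bonds along the chain from an oxygen on an aromatic ring. Within the data shown here, no measured pair shows this change on its own. Given that compound 2 gives 0.5 10^-6 cm/s and compound 3 gives 3.2 10^-6 cm/s, a modest upward step is expected, a 2.4-fold higher number from compound 2 to compound 4 (0.38 log units; beyond the scatter), though one that may not clear the scatter. Compound 4 is estimated at 1.2 10^-6 cm/s in this assay, within a range of 0.4 10^-6 cm/s to 3.5 10^-6 cm/s.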

Compound 4, apparent permeability: 1.5 10^-6 cm/s
For compound 4 the middle estimate is 1.3-fold (0.10 log units) below the measured one; the measured number falls inside the stated range.
By their numbers in this assay, from the lowest: compounds 2, 1 and 4 (each within the scatter of the next, the first and the last beyond it); then compound 3.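

In this assay, among these compounds, 3-fluoro-2-methylphenyl in place of 2,3,5,6-tetrafluorophenyl on a saturated chain carbon, four bonds along the chain from an oxygen on an aromatic ring, gives a 3.0-fold higher number from compound 2 to compound 4 (0.48 log units; beyond the scatter) and is the first step that can be read from a single change. The aryl group at the end of this chain is therefore enough on its own to move the read-out beyond the scatter while the rest of the molecule stays fixed. No measurement at hand offers an explanation for the step, which stands as an observation only.

From the compounds shown here alone, the pair cannot separate the methyl from the changed fluorine pattern, and a plain phenyl or a pyridine ring at this place remains open. Also open, going by these compounds, is whether the step carries over to the compounds with a triple bond, such as compound 3.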